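This account rests on a few compounds, and the source may have more. Where it says the series, first, only, none or still open, it means among the compounds named here.

Measured in a functional assay on DU-145 cells (Homo sapiens) for cytotoxicity, read by ELISA, with a stated time of 2 days; a higher number here means a weaker inhibitor, a lower number a stronger inhibitor:
- Compound 1 `Oc1ccccc1-c1cc(-c2ccccc2)cc(-c2ccccc2O)n1`: 8000 nM
- Compound 2 `Oc1cccc(-c2cc(-c3ccccc3)cc(-c3ccco3)n2)c1`: 14400 nM
- Compound 3 `Oc1cccc(-c2cc(-c3ccccc3)nc(-c3ccccc3)c2)c1`: 17900 nM

Compound 3 lies within the usual scatter of compound 2, but beyond the scatter from compound 1, which has the lower number. Compound 4 `Oc1cccc(-c2cc(-c3ccccc3)nc(-c3ccco3)c2)c1` carries furan-2-yl in place of phenyl on an aromatic carbon, next to the ring nitrogen: furan-2-yl in place of phenyl on an aromatic carbon. Compound 2 also carries furan-2-yl, although it differs from compound 3 in more than one place. The value of compound 2 at 14400 nM gives little reason to expect a large change in this assay. The expected result is a small step, a 1.2-fold lower number from compound 3 to compound 4 (0.08 log units; within the scatter), within the scatter and with no firm direction. The estimate for compound 4 is 15000 nM, with an expected range of 7000 nM to 32000 nM.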

Compound 4, half-maximal inhibitory concentration: 34900 nM
Compound 4: the middle estimate sits 2.3-fold (0.37 log units) below what was measured; measured number above the stated range.
By their numbers in this assay, from the lowest: compounds 1, 2, 3 and 4 (each within the scatter of the next, the first and the last beyond it).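

Replacing phenyl with furan-2-yl on the aromatic carbon next to the ring nitrogen gives a 1.9-fold higher number from compound 3 to compound 4 (0.29 log units; within the scatter) in this assay. Among these compounds, this is the first comparison here in which only one place differs, and it shows no firm effect of exchanging the six-membered carbon ring for the five-membered oxygen-containing ring at this position. Nothing available explains the result.

As far as these compounds go, how an amine or a carboxylic acid on this carbon would read remains open. So does whether the same exchange would give a similar step on the core of compound 1.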